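The source may report more compounds than this note shows. Statements on the series, on what has been measured and on what is new or still open speak of the compounds shown alone.

Measured in a functional assay on HeLa cells (Homo sapiens) for inhibition, read by CCK-8 assay, with a stated time of 48 h; a higher number here means a weaker inhibitor, a lower number a stronger inhibitor:
- Compound 1 `COc1ccc(Oc2ccc(C(C)C)cc2-c2ccsc2S(=O)(=O)NCCNC(=S)Nc2ccc([N+](=O)[O-])cc2)cc1OC`: 11900 nM
- Compound 2 `O=C(NCCNS(=O)(=O)c1ccc(-c2ccccc2O[C@H]2CC[C@@H](O)CC2)s1)Nc1ccc([N+](=O)[O-])cc1`: > 20000 nM (a limit, not a number)
- Compound 3 `O=[N+]([O-])c1ccc(NC(=S)NCCNS(=O)(=O)c2ccc(-c3ccccc3O[C@H]3CC[C@@H](O)CC3)s2)cc1`: > 20000 nM (a limit, not a number)

Compound 3 has only a limit, and it stands at the limit of > 20000 nM in this assay, at which 2 of the 3 values shown sit. Compound 4 `O=[N+]([O-])c1ccc(NC(=S)NCCNS(=O)(=O)c2ccc(-c3ccccc3O[C@H]3CC[C@H](O)CC3)s2)cc1` relates to compound 3 as follows: the two compounds have the same atoms and bonds and differ only in configuration as drawn: 2 of 2 stereo elements differ (all stereocentres are inverted: mirror images); a stereocentre at a saturated ring carbon is drawn s in compound 3 and r in compound 4; a stereocentre at a saturated ring carbon is drawn s in compound 3 and r in compound 4.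

Among the compounds with values here, the one measured step, a step that the two limits leave unreadable from compound 2 to compound 3, lies elsewhere in the molecule and gives no size to carry over. Within the data shown here, no measured step involves a change of configuration alone. No step beyond the usual scatter is therefore expected in this assay, in either direction, and another limit is the likeliest result. The expected change is a step that the limit leaves unreadable from compound 3 to compound 4. For compound 4 the estimate is 25000 nM, with an expected range of 12000 nM to 50000 nM.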

Compound 4, half-maximal inhibitory concentration: 5400 nM
Compound 4: middle estimate off by 4.6-fold (0.67 log units), on the high side; the whole stated range lies above it.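

In this assay, within the data shown here, configuration at the two saturated ring carbons turns out to matter, which no earlier pair could show: the change is an at least 3.7-fold lower number from compound 3 to compound 4 (0.56 log units; beyond the scatter). The value for compound 3 is a limit, not a number, so this size is only a minimum: the limit of > 20000 nM in this assay, at which 2 of the 4 values shown sit. The shift can be assigned to configuration alone, because nothing else changes: the fact that compounds 3 and 4 differ only in the configuration as drawn

From the compounds shown here alone, how large the true gap is remains open, as does whether one ring carbon alone accounts for it. Going by these compounds, it is also open whether an amine in place of the hydroxyl group on the saturated ring would keep the lower number of compound 4.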